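The compounds below may be only part of what the source reports. "The series", "measured", "known", "first", "only" and "open" are said of these compounds alone.

Measured so far:
compound 1 `CCO/C(O)=C1\C(COCCn2ccnn2)=NC(C)=C(C(=O)OC)C1c1cccc(Cl)c1Cl` — 5.01 nM
compound 2 `CCO/C(O)=C1\C(COCCN2CC(=O)NC2=O)=NC(C)=C(C(=O)OC)C1c1ccccc1Cl` — 20 nM

In a functional assay (aorta) with Rattus norvegicus as the target (on this read-out higher numbers stand for weaker inhibition and lower numbers for stronger inhibition), compound 2 gives 20 nM, the highest of the two numbers recorded; compound 1 gives 5.01 nM, a gap that lies beyond the scatter. Compounds 1 and 2 differ in more than one place, so nothing is read from that pair about any single change.

Compound 3 `CCO/C(O)=C1\C(COCCn2cnc3ccccc32)=NC(C)=C(C(=O)OC)C1c1ccccc1Cl` is not yet measured. It differs from compound 2 in one place: 1H-benzimidazol-1-yl in place of 2,4-dioxoimidazolidin-1-yl on a saturated chain carbon, two bonds along the chain from an oxygen on a saturated carbon. Among the measured compounds shown here, no measured pair covers this exact change, so the expectation rests on the two numbers alone. For compound 3 a modest move towards a lower number in this assay is expected, roughly at the edge of the scatter, with the estimated step of a 2.5-fold lower number from compound 2 to compound 3 (0.40 log units; beyond the scatter). Compound 3 is expected to give about 8 nM. For compound 3 the range is estimated from 2 nM to 35 nM.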

Compound 3, half-maximal inhibitory concentration: 20 nM
The estimate for compound 3 lay 2.5-fold (0.40 log units) below the measured number; measured number inside the range.
By their numbers in this assay, from the lowest: compound 1; then compounds 2 and 3 (each within the scatter of the next).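

In this assay, the exchange of 2,4-dioxoimidazolidin-1-yl for 1H-benzimidazol-1-yl on a saturated chain carbon, two bonds along the chain from an oxygen on a saturated carbon, gives no change at the digits printed from compound 2 to compound 3 (within the scatter). This position therefore accepts two quite different ring groups with no measurable shift in the read-out: the entering group has two aromatic rings and 0 hydrogen-bond donors, while the leaving group has one non-aromatic ring and 1 hydrogen-bond donor. The data on hand offer no explanation for this flat step.

As far as these compounds go, whether the same position would also accept a simple amine, a carboxylic acid or a longer chain remains open. Compound 1, at 5.01 nM, differs from compound 2 and compound 3 in more than one place, so no single change can account for its value.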